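Removing the distal phenyl from a biphenyl iminosugar analogue

The compounds below may be only part of what the source reports. "The series", "measured", "known", "first", "only" and "open" are said of these compounds alone.

The series is built around a polyhydroxylated pyrrolidine bearing an aromatic substituent, and the readout is an assay on isolated protein for inhibition of alpha-galactosidase (Coffea arabica), read by spectrophotometry, tested at 1000 uM; on this read-out higher numbers stand for more inhibition at the one concentration tested (going by the name of the read-out) and lower numbers for less inhibition. Compound 1 `O[C@@H]1[C@@H](O)CN[C@H]1c1ccccc1` carries a plain phenyl on the shared core and in this assay compound 1 gives 2.6%. Compound 2 `O[C@H]1[C@H](O)CN[C@@H]1c1ccc(-c2ccccc2)cc1` carries a biphenyl instead, and in this assay compound 2 gives 0%. Compound 2 thus sits at the floor of the two readings, but its gap to compound 1 is within the usual scatter, so the two measured compounds cannot be told apart on these numbers; both show essentially no inhibition at the concentration tested.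

Compound 3 `O[C@H]1[C@H](O)CN[C@@H]1c1ccccc1` has not yet been measured. It differs from compound 2 in one place: hydrogen in place of phenyl on an aromatic carbon. Within the data shown here, no step between measured compounds is available to calibrate this change. Given that compound 2 gives 0% and compound 1, the other measured member of the series, gives 2.6%, the expectation for the step is none beyond the scatter, and the step from compound 2 to compound 3 is estimated at a number 2 percentage points higher from compound 2 to compound 3 (within the scatter). Compound 3 is therefore expected to give 2%, within a range of 0% to 10%.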

Compound 3, a percentage reported as inhibition, at one concentration (the size of the read-out at that concentration, not a potency): 8.6%
For compound 3 the middle estimate is 6.6 percentage points below the measured one; low and high end bracket the measured number.
By their numbers in this assay, from the lowest: compounds 2, 1 and 3 (each within the scatter of the next).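

In this assay, the hydrogen in place of phenyl on an aromatic carbon, para to a group of 7 heavy atoms, gives a step of a number 8.6 percentage points higher from compound 2 to compound 3 (within the scatter), so removing this phenyl produces no difference that can be separated from the usual scatter of the measurement. Among these compounds, the earlier compounds offered no step at this position, and this is the first evidence that the distal ring neither adds to nor takes away from the reading by a margin these data can resolve. The mirror-image pair gives a number 6 percentage points higher from compound 1 to compound 3 (within the scatter), so inverting all the stereocentres also leaves the compounds indistinguishable, and this comparison bears on configuration alone: the fact that compounds 1 and 3 differ only in the configuration as drawn

As far as these compounds go, it remains open whether a different group on this aromatic carbon, such as an amine, a carboxylic acid or a methoxy group, would lift the reading clear of the scatter. With only one enzyme and one concentration in view, these compounds also leave open whether the two mirror-image forms of the shared core would separate under another read-out.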